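Replacing the Amino Group of Compound 2

The source may hold more compounds than are shown below. What is called first, only, known or untested is meant among the compounds shown, and "the series" means these compounds.

Measured in a functional assay on U-937 cells (Homo sapiens) for cytotoxicity, read by MTT assay, with a stated time of 3 days; a lower number here means a stronger inhibitor, a higher number a weaker inhibitor:
- compound 1 `N#Cc1c(Cl)nc(SCc2nc3ccccc3[nH]2)nc1-c1ccccc1`: 4.46 nM
- compound 2 `N#Cc1c(NN)nc(SCc2nc3ccccc3[nH]2)nc1-c1ccccc1`: 3.9 nM
- compound 3 `CNc1nc(SCc2nc3ccccc3[nH]2)nc(-c2ccccc2)c1C#N`: 19.2 nM

Compound 2 shares the low end of these numbers with compound 1, and the step between them is a 1.1-fold lower number from compound 1 to compound 2 (0.06 log units; within the scatter). Compound 3 stands apart from both. The unmeasured compound 4 `N#Cc1c(NC(N)=S)nc(SCc2nc3ccccc3[nH]2)nc1-c1ccccc1` differs from compound 2 in one place: a group of 3 heavy atoms (1 carbon, 1 nitrogen, 1 sulfur; no ring) in place of one nitrogen atom, on a nitrogen on an aromatic ring. The amino group leaves, and the new group sits on the same nitrogen.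

The closest guide is the other measured replacement of that amino group, a 4.9-fold higher number from compound 2 to compound 3 (0.69 log units; beyond the scatter). This step is modest, and a 4.3-fold higher number from compound 1 to compound 3 (0.63 log units; beyond the scatter) is of similar size. Compound 1 offers less guidance, since it has chloro where the others have a nitrogen group. Among the measured compounds shown here, no measured compound carries the entering group, so the direction rests on compound 3 alone and remains uncertain. A modest move to a higher number is expected in this assay, and the estimated step is a 2.6-fold higher number from compound 2 to compound 4 (0.41 log units; beyond the scatter). Compound 4 is estimated at 10 nM, with an expected range of 3 nM to 35 nM.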

Compound 4, half-maximal inhibitory concentration: 20 nM
The estimate for compound 4 lay 2.0-fold (0.30 log units) below the measured number, within the range that was stated.
By their numbers in this assay, from the lowest: compounds 2 and 1 (each within the scatter of the next); then compounds 3 and 4 (each within the scatter of the next).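

In this assay, a 5.1-fold higher number from compound 2 to compound 4 (0.71 log units; beyond the scatter) shows that the higher number seen with methyl in compound 3 is not unique to that group, since this group of 3 heavy atoms in place of the amino group on the same nitrogen also gives one. The two replacements cannot be told apart, with a 1.0-fold higher number from compound 3 to compound 4 (0.02 log units; within the scatter) lying within the scatter even though they differ in their atoms. Among the compounds shown here, measured against chloro, a 4.5-fold higher number from compound 1 to compound 4 (0.65 log units; beyond the scatter) leaves the amino group of compound 2 as the only nitrogen group here that stays level with compound 1.

Nothing measured here explains why the amino group stands apart from these two replacements. An ethyl group on that nitrogen, or a plain amine in its place on the aromatic carbon, could show whether the higher number holds for other groups.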